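The source may report more compounds than this note shows. Statements on the series, on what has been measured and on what is new or still open speak of the compounds shown alone.

Measured so far in an assay on HL-60 cells for inhibition of cytochrome P450 26A1 (Homo sapiens), read by HPLC, using microsomes and NADPH, with a stated time of 30 min; on this read-out higher numbers stand for weaker inhibition and lower numbers for stronger inhibition:

compound 1, `CCOC(=O)C(Cn1ccnc1)NC(=O)c1ccc(-c2ccccc2)cc1`, 650 nM
compound 2, `CC(C)OC(=O)C(Cn1ccnc1)NC(=O)c1ccc(-c2ccccc2)cc1`, 540 nM

Compound 1 gives the highest of the two numbers; compound 2 sits within the scatter of it, the step being a 1.2-fold lower number from compound 1 to compound 2 (0.08 log units; within the scatter). Compound 3, `CC(C)COC(=O)C(Cn1ccnc1)NC(=O)c1ccc(-c2ccccc2)cc1`, is not yet measured. It differs from compound 1 by isopropyl in place of methyl on a saturated chain carbon bound to an oxygen next to a carbonyl group. Among the compounds with values here, the only step that bears on this change is the one from compound 1 to compound 2, a growth at the same place, and it was within the scatter. A step of similar kind, perhaps slightly larger, is therefore expected for compound 3: a 1.4-fold lower number from compound 1 to compound 3 (0.16 log units; within the scatter). Compound 3 is estimated at 450 nM, in a range from 200 nM to 1200 nM.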

Compound 3, half-maximal inhibitory concentration: 970 nM
Beside the measured number, compound 3's estimate is 2.2-fold (0.33 log units) below it; measured number inside the range.
By their numbers in this assay, from the lowest: compounds 2, 1 and 3 (each within the scatter of the next).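

Isobutyl in place of ethyl at this position (a 1.5-fold higher number from compound 1 to compound 3 (0.17 log units; within the scatter)) stays within the scatter in this assay, and so does isobutyl in place of isopropyl (a 1.8-fold higher number from compound 2 to compound 3 (0.25 log units; within the scatter)). The read-out therefore does not separate the three groups on the oxygen next to the carbonyl group, even with the added bulk of isobutyl. No measurement at hand explains this. Still open, from the compounds shown here alone, is whether a longer chain, a phenyl ring or a free carboxylic acid at this place would move the number beyond the scatter.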